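Replacing a hexyl chain with a trifluoromethylphenyl group

This account rests on a few compounds, and the source may have more. Where it says the series, first, only, none or still open, it means among the compounds named here.

compound 1 `CCCCCCNc1nc(SCc2ccc(C(F)(F)F)cc2)nc2ccccc12`: 23900 nM in a functional assay on HGC-27 cells (Homo sapiens) for cytotoxicity, read by MTT assay, with a stated time of 72 h; on this read-out higher numbers stand for weaker inhibition and lower numbers for stronger inhibition
compound 2 `COc1ccccc1Nc1nc(SCc2ccc(C(F)(F)F)cc2)nc2ccccc12`: > 50000 nM in this assay

Among the compounds with values here, compound 1 holds the only measured number in this assay. Compound 2 reaches only a limit of > 50000 nM in this assay. Within the data shown here, the step of an at least 2.0-fold higher number from compound 1 to compound 2 (0.32 log units; beyond the scatter) is the one measured change that bears on compound 3. Compound 3 `FC(F)(F)c1ccc(CSc2nc(Nc3cccc(C(F)(F)F)c3)c3ccccc3n2)cc1` differs from compound 1 in that (3-(trifluoromethyl)phenyl in place of hexyl on a nitrogen on an aromatic ring). Since the comparable exchange gave an at least 2.0-fold higher number from compound 1 to compound 2 (0.32 log units; beyond the scatter), a weakening of similar size is expected, a 2.5-fold higher number from compound 1 to compound 3 (0.40 log units; beyond the scatter). Compound 3 is therefore estimated at 60000 nM, from 25000 nM to 200000 nM, and it may well sit at the limit of > 50000 nM in this assay, at which 1 of the 2 values shown sits.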

Compound 3, half-maximal inhibitory concentration: 11700 nM
Beside the measured number, compound 3's estimate is 5.1-fold (0.71 log units) above it; measured number below the stated range.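

In this assay, an aromatic ring on this nitrogen does not by itself cost activity: putting 3-(trifluoromethyl)phenyl in place of hexyl gives a 2.0-fold lower number from compound 1 to compound 3 (0.31 log units; beyond the scatter). Which aromatic group sits there matters, with an at least 4.2-fold lower number from compound 2 to compound 3 (0.63 log units; beyond the scatter). The value of compound 2 is a limit: the limit of > 50000 nM in this assay, at which 1 of the 3 values shown sits.

Going by these compounds, whether the gain rests on the trifluoromethyl group or on the ring alone stays open, and a plain phenyl group on this nitrogen would speak to that. On these data alone, how a carboxylic acid or an amine on that ring would fare is also open.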